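Extending the ethyl on the nitrogen of compound 3

The source may hold more compounds than are shown below. What is called first, only, known or untested is meant among the compounds shown, and "the series" means these compounds.

Compound 3 `CCn1c(-c2ccccc2)nc2c(NC3CCC3)ncnc21` gives 1440 nM in a functional assay on CHO cells for antagonist activity at adenosine receptor A2b (Homo sapiens), read by 33P incorporation, with a stated time of 20 min (a higher number here means a weaker inhibitor, a lower number a stronger inhibitor), and stands at the low end of the three numbers shown. Going by the values given here, compound 2 `Cn1c(-c2cccc(Cl)c2)nc2c(NC3CCCC3)ncnc21` gives 2530 nM, within the scatter of compound 3, while compound 1 `CCn1c(-c2ccccc2)nc2c(NC3CCCCC3)ncnc21` gives 9020 nM; the step of a 6.3-fold lower number from compound 1 to compound 3 (0.80 log units; beyond the scatter) is the only single-point step among the measured compounds. Compound 4 `CCCn1c(-c2ccccc2)nc2c(NC3CCC3)ncnc21` differs from compound 3 by methyl in place of hydrogen on a saturated chain carbon, two bonds along the chain from an aromatic nitrogen. Among the compounds with values here, no measured step touches this position alone; compound 2 carries a methyl on that nitrogen but also differs from compound 3 elsewhere, so its value shows no more than that a methyl there sits within the scatter of compound 3. The step of a 1.2-fold lower number from compound 3 to compound 4 (0.08 log units; within the scatter) is therefore expected to stay within the scatter. Compound 4 is estimated at 1200 nM, with a range from 400 nM to 4000 nM.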

Compound 4, inhibition constant: 774 nM
Estimate against measurement, compound 4: 1.6-fold (0.19 log units) above; the measured number falls inside the stated range.
By their numbers in this assay, from the lowest: compounds 4, 3 and 2 (each within the scatter of the next, the first and the last beyond it); then compound 1.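

Ethyl to propyl gives the first single-point reading at this position: in this assay, the step is a 1.9-fold lower number from compound 3 to compound 4 (0.27 log units; within the scatter). The added methyl, on a saturated chain carbon, two bonds along the chain from an aromatic nitrogen, therefore leaves the number within the scatter. No available evidence bears on this result. Still open, going by these compounds, is whether a longer chain such as butyl, or a chain ending in an amine or a carboxylic acid, would hold the number there. Also open, on these data alone, is whether propyl behaves alike with the cyclohexyl of compound 1.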